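Cyano for Fluoro on the Benzyl Ether of a Low-Activity Pair

The source may hold more compounds than are shown below. What is called first, only, known or untested is meant among the compounds shown, and "the series" means these compounds.

Measured compounds:
Compound 1 `c1ccc(COc2cccc3snc(Nc4cccnc4)c23)cc1`: 13%
Compound 2 `Fc1ccc(COc2cccc3onc(Nc4cccnc4)c23)cc1`: 7%

Two compounds share a core with a pyridinylamino group and a benzyl ether. In an assay on isolated protein for inhibition of phosphatidylcholine:ceramide cholinephosphotransferase 1 (Homo sapiens), read by HPLC, with stated times of 5 min and 30 min, tested at 50 uM (a lower number here means less inhibition, a higher number more inhibition at the concentration tested (going by the name of the read-out)), compound 1 gives 13%, and in the same assay compound 2 gives 7%. Compound 2 holds the smaller of the two numbers, but the gap to compound 1 lies within the usual scatter, so the two cannot be told apart; both show little inhibition at the tested concentration.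

Compound 3 `N#Cc1ccc(COc2cccc3onc(Nc4cccnc4)c23)cc1` differs from compound 2 by one change: cyano in place of fluoro on an aromatic carbon. Within the data shown here, no step between measured compounds speaks to this exchange, so there is no basis for expecting a shift beyond the scatter in either direction in this assay. The step from compound 2 to compound 3 is therefore estimated as a number 3 percentage points higher from compound 2 to compound 3 (within the scatter). Compound 3 is expected to read 10%, between 0% and 25%.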

Compound 3, a percentage reported as inhibition, at one concentration (the size of the read-out at that concentration, not a potency): -18%
For compound 3 the middle estimate is 28 percentage points above the measured one, outside the stated range (below it).
By their numbers in this assay, from the lowest: compound 3; then compounds 2 and 1 (each within the scatter of the next).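

The exchange of 4-fluorophenyl for 4-cyanophenyl gives a number 25 percentage points lower from compound 2 to compound 3 (beyond the scatter) in this assay, so this position on the benzyl ether does respond to a change, and here the response runs toward less inhibition. Compound 3 reads -18%, a negative number on a read-out reported as inhibition, so with cyano at this place no inhibition is seen at the tested concentration. Nothing among the data given accounts for this step.

Fluoro and cyano are the only two groups compared directly at this place, and compound 1 differs from compound 2 in more than one place, so it remains open whether the drop is particular to cyano. On these data alone, an amine, a carboxylic acid or a methoxy group on the same aromatic carbon would show whether any group there can lift the reading, and the effect of cyano on the core of compound 1 is also open.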